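This account rests on a few compounds, and the source may have more. Where it says the series, first, only, none or still open, it means among the compounds named here.

In a functional assay on DU-145 cells (Homo sapiens) for inhibition, read by trypan blue exclusion, with a stated time of 72 h (a higher number here means a weaker inhibitor, a lower number a stronger inhibitor), compound 3 (`Cn1c(=O)c(S(=O)(=O)c2ccc(Cl)cc2)cc2cnc(Nc3ccc4[nH]ccc4c3)nc21`) gives 250 nM, the lowest of the three numbers and so the strongest inhibitor measured so far. Compound 1 (`Cn1c(=O)c(S(=O)(=O)c2ccc(Cl)cc2Cl)cc2cnc(Nc3ccc4[nH]ccc4c3)nc21`) gives 1000 nM, and compound 2 (`Cn1c(=O)c(C(=O)Nc2ccc(F)cc2F)cc2cnc(Nc3ccc4[nH]ccc4c3)nc21`) gives 5000 nM. Compound 4 (`Cc1ccc(S(=O)(=O)c2cc3cnc(Nc4ccc5[nH]ccc5c4)nc3n(C)c2=O)cc1`) carries methyl in place of chloro on an aromatic carbon, turning the (4-chlorophenyl)sulfonyl group into (4-methylphenyl)sulfonyl: methyl in place of chloro on an aromatic carbon.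

The closest evidence is the modest 4.0-fold lower number from compound 1 to compound 3 (0.60 log units; beyond the scatter), where hydrogen replaces chloro on the same aryl sulfonyl group. Among the compounds with values here, that step is only an indirect guide, as no measured compound has methyl there and no measured pair changes that exact chloro. The large 20-fold lower number from compound 2 to compound 3 (1.30 log units; beyond the scatter) and the modest 5.0-fold higher number from compound 1 to compound 2 (0.70 log units; beyond the scatter) both exchange the whole group, so they say little about a single swap of this kind.

In this assay, a small change is therefore expected, probably no step beyond the scatter, with a slight loss more likely than a gain. The estimated step is a 1.2-fold higher number from compound 3 to compound 4 (0.08 log units; within the scatter). Compound 4 is expected to give about 300 nM, within an estimated range of 110 nM to 850 nM.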

Compound 4, half-maximal inhibitory concentration: 750 nM
For compound 4 the middle estimate is 2.5-fold (0.40 log units) below the measured one; measured number inside the range.
By their numbers in this assay, from the lowest: compound 3; then compounds 4 and 1 (each within the scatter of the next); then compound 2.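

The direct step at this position, a 3.0-fold higher number from compound 3 to compound 4 (0.48 log units; beyond the scatter) in this assay, shows that the exchange from 4-chlorophenyl to 4-methylphenyl on the sulfonyl group is not neutral: chloro gives the lower number here. The change from 2,4-dichlorophenyl to 4-methylphenyl on the sulfonyl sulfur stays within the scatter, a 1.3-fold lower number from compound 1 to compound 4 (0.12 log units; within the scatter), while the (4-methylphenyl)sulfonyl group still gives a clearly lower number than the (2,4-difluorophenyl)carbamoyl group, a 6.7-fold lower number from compound 2 to compound 4 (0.82 log units; beyond the scatter). Nothing measured here explains the gap between chloro and methyl at this position.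

The compounds shown leave open how a methoxy group, an amine or a carboxylic acid would behave at this position on the phenyl ring. They also leave open whether chloro would still give the lower number than methyl with a second substituent on that ring.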